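Swapping a thioether chain for a branched alkyl

The source may hold more compounds than are shown below. What is called first, only, known or untested is meant among the compounds shown, and "the series" means these compounds.

Three compounds have been measured so far:
compound 1, `COCCCn1c(N2CCN(C)CC2)nc2ccccc21`, 860 nM;
compound 2, `CCCCOCCn1c(N2CCN(C)CC2)nc2ccccc21`, 38 nM;
compound 3, `CCSCCCn1c(N2CCN(C)CC2)nc2ccccc21`, 530 nM.

All three were tested in a functional assay on ileum for inhibition of histamine H1 receptor (Cavia porcellus); on this read-out higher numbers stand for weaker inhibition and lower numbers for stronger inhibition. Compound 3 gives the second highest of the three numbers. Its nearest neighbour is compound 1, and the change from compound 1 to compound 3 is a 1.6-fold lower number from compound 1 to compound 3 (0.21 log units; within the scatter), so the two cannot be told apart. Compound 2 lies much further off: the step from compound 2 to compound 3 is a 14-fold higher number from compound 2 to compound 3 (1.14 log units; beyond the scatter).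

Compound 4 is `CCCC(C)n1c(N2CCN(C)CC2)nc2ccccc21`. It differs from compound 3 in one place: 1-methylbutyl in place of 3-(ethylsulfanyl)propyl on an aromatic nitrogen. The chain that leaves carries one hydrogen-bond acceptor; the chain that enters carries none and is branched.

The measured steps all alter the chain on this aromatic nitrogen. The step from compound 1 to compound 2 was a 23-fold lower number from compound 1 to compound 2 (1.35 log units; beyond the scatter), and the step from compound 2 to compound 3 was a 14-fold higher number from compound 2 to compound 3 (1.14 log units; beyond the scatter), so changes in this chain can move this assay a great deal, in either direction. Among the compounds with values here, no measured step removes the acceptor altogether or introduces branching, so there is no close precedent for the change in compound 4.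

Given that gap, the expected step from compound 3 to compound 4 in this assay is a 1.3-fold lower number from compound 3 to compound 4 (0.12 log units; within the scatter), with a wide range. Compound 4 is estimated at 400 nM, between 80 nM and 2000 nM.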

Compound 4, half-maximal inhibitory concentration: 1400 nM
Compound 4: middle estimate off by 3.5-fold (0.54 log units), on the low side; low and high end bracket the measured number.
By their numbers in this assay, from the lowest: compound 2; then compounds 3, 1 and 4 (each within the scatter of the next, the first and the last beyond it).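

In this assay, the chain on this aromatic nitrogen can do without a sulfur atom and still leave a measurable effect, though not a large one: the step to 1-methylbutyl is a 2.6-fold higher number from compound 3 to compound 4 (0.42 log units; beyond the scatter), whereas replacing 2-butoxyethyl with the same group gives a 37-fold higher number from compound 2 to compound 4 (1.57 log units; beyond the scatter). Compound 4 cannot be told apart from compound 1, with a 1.6-fold higher number from compound 1 to compound 4 (0.21 log units; within the scatter), so a branched chain with no hydrogen-bond acceptor sits at the weak end of this small set, and compound 2 remains the strongest inhibitor of the four. No measurement offered here explains why these chains differ.

In compound 4 the hydrogen-bond acceptor is lost and branching is gained in a single change, so the compounds shown cannot say which of the two lies behind the step from compound 3. An unbranched pentyl chain on the same aromatic nitrogen would separate the two, and a 2-pentoxyethyl chain would show whether the low number of compound 2 holds when its butoxy group is lengthened.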